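A few compounds are considered here, and "the series" means these few. Any claim that something is new, unique, unknown or untested is made for them only; others in the source may bear on it.

A small set of compounds built on one shared core was examined in a functional assay on COLO 205 cells (Homo sapiens) for cytotoxicity, read by MTT assay, with a stated time of 48 h; on this read-out lower numbers stand for stronger inhibition and higher numbers for weaker inhibition. Compound 1 `O=c1ccc2cc(OCc3cc(-c4ccccc4Cl)no3)ccc2o1` carries a 2-chlorophenyl group on an aromatic carbon of a five-membered aromatic ring with 1 nitrogen and 1 oxygen; in this assay compound 1 gives "not determined" (no result reported), so it stands without a number. Compound 3 `COc1cccc(-c2cc(COc3ccc4oc(=O)ccc4c3)on2)c1` is in the same position: in this assay compound 3 gives "not determined" (no result reported). Among the measured compounds shown here, the only number in the set comes from compound 2 `O=c1ccc2cc(OCc3cc(-c4ccc5ccccc5c4)no3)ccc2o1`; in this assay compound 2 gives 48700 nM, a weak effect on these cells.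

Compound 4 `O=c1ccc2cc(OCc3cc(-c4ccc(Cl)cc4)no3)ccc2o1` has not yet been measured. The change from compound 1 to compound 4 is 4-chlorophenyl in place of 2-chlorophenyl on an aromatic carbon. The two compounds have the same atoms, joined differently. For the measured compounds named here, compound 1 has no number, and no measured step exists to lean on. The expectation is that this exchange leaves the result in this assay near what compound 2 shows, with any difference staying within the scatter of this kind of measurement. Compound 4 is therefore expected to give about 40000 nM in this assay, with a range from 12000 nM to 130000 nM.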

Compound 4, half-maximal inhibitory concentration: 44500 nM
The estimate for compound 4 lay 1.1-fold (0.05 log units) below the measured number, and the stated range covers the measured number.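

In this assay, among the compounds shown here, compound 1 has no number, so no measured step links it to compound 4, which gives 44500 nM on its own. The compounds shown leave open whether 2-chlorophenyl and 4-chlorophenyl differ in their effect on these cells. Nothing given here offers an explanation for the result of compound 4.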